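Chloro on the benzyl ring in a cyclopentylamino series

The source may hold more compounds than are shown below. What is called first, only, known or untested is meant among the compounds shown, and "the series" means these compounds.

Compound 1 `CCCCCCNc1nc(-c2ccccc2)nc2c1nnn2Cc1ccccc1` and compound 2 `CCCCCCNc1nc(-c2ccccc2)nc2c1nnn2Cc1ccccc1Cl` differ by chloro in place of hydrogen on an aromatic carbon. In an assay on Cerebral cortex for displacement of a labelled ligand from adenosine receptor A1 (Bos taurus) (a lower number here means a stronger inhibitor, a higher number a weaker inhibitor), compound 1 gives 13.2 nM and compound 2 gives 31 nM, a step of a 2.3-fold higher number from compound 1 to compound 2 (0.37 log units; beyond the scatter). Compound 3 `c1ccc(Cn2nnc3c(NC4CCCC4)nc(-c4ccccc4)nc32)cc1` carries the change cyclopentyl in place of hexyl on a nitrogen on an aromatic ring relative to compound 1; in this assay compound 3 gives 11 nM, and the step of a 1.2-fold lower number from compound 1 to compound 3 (0.08 log units; within the scatter) lies within the scatter. Compound 4 `Clc1ccccc1Cn1nnc2c(NC3CCCC3)nc(-c3ccccc3)nc21` differs from compound 3 by chloro in place of hydrogen on an aromatic carbon, the same change as from compound 1 to compound 2, at the same kind of place. Because the step of a 2.3-fold higher number from compound 1 to compound 2 (0.37 log units; beyond the scatter) was modest and beyond the scatter, the number for compound 4 is expected to rise by about a 2.3-fold higher number from compound 3 to compound 4 (0.36 log units; beyond the scatter) from compound 3. Compound 4 is thus estimated at 25 nM, between 12 nM and 55 nM.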

Compound 4, inhibition constant: 9 nM
For compound 4 the middle estimate is 2.8-fold (0.44 log units) above the measured one; the whole stated range lies above it.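

With cyclopentyl on the nitrogen, chloro in place of hydrogen gives a 1.2-fold lower number from compound 3 to compound 4 (0.09 log units; within the scatter) in this assay, so the rise seen with hexyl did not carry over: the same change on two cores in this assay, a 2.3-fold higher number (0.37 log units; beyond the scatter) from compound 1 to compound 2 and a 1.2-fold lower number (0.09 log units; within the scatter) from compound 3 to compound 4, 2.9-fold (0.46 log units) apart, beyond the scatter of two such steps. Read the other way, cyclopentyl in place of hexyl gives a 3.4-fold lower number from compound 2 to compound 4 (0.54 log units; beyond the scatter) with the chloro present, a larger step than without it: the same change on two cores in this assay, a 1.2-fold lower number (0.08 log units; within the scatter) from compound 1 to compound 3 and a 3.4-fold lower number (0.54 log units; beyond the scatter) from compound 2 to compound 4, 2.9-fold (0.46 log units) apart, beyond the scatter of two such steps. These four compounds thus show that the effect of either change depends on the other, but a single pair of steps cannot show why, or whether this holds beyond them.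

The compounds shown leave open whether fluoro or methoxy on the benzyl ring would behave as chloro does. On these data alone, it also remains open whether a longer chain or cyclohexyl on the nitrogen would follow hexyl or cyclopentyl.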